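The compounds below may be only part of what the source reports. "The series", "measured", "known", "first", "only" and "open" are said of these compounds alone.

Compound 1 `Cc1ccc(SCc2ccc(C(=O)Nc3ccccc3N)cc2)cc1` was tested in a functional assay on HeLa cells (Homo sapiens) for inhibition, read by CCK-8 assay, with a stated time of 72 h, tested at 8 uM (on this read-out higher numbers stand for more inhibition of growth at the one concentration tested and lower numbers for less inhibition of growth), where compound 1 gives 79.2%. That is the highest of the three numbers seen so far. Compound 2 `CC(C)(C)c1ccc(SCc2ccc(C(=O)Nc3ccccc3N)cc2)cc1` gives 40.2%, and compound 3 `COC(=O)c1ccccc1SCc1ccc(C(=O)Nc2ccccc2N)cc1` gives 55.5%, both clearly below compound 1. Going by the values given here, the only single-point step measured so far runs a number 39 percentage points lower from compound 1 to compound 2 (beyond the scatter). Compound 4 `Nc1ccccc1NC(=O)c1ccc(CSCCc2ccccc2)cc1` has not yet been measured. It differs from compound 1 by phenethyl in place of 4-methylphenyl on a sulfur. Among the compounds with values here, no measured pair exchanges the whole ring that hangs on the sulfur for a chain, so the nearest guide is the step from compound 1 to compound 2, which shows that changing the group on that side of the molecule can cost a great deal. Because of that large fall a number 39 percentage points lower from compound 1 to compound 2 (beyond the scatter), a moderate drop is expected here, a number 24.2 percentage points lower from compound 1 to compound 4 (beyond the scatter). The estimate for compound 4 is 55%, with a range from 30% to 80%.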

Compound 4, percent growth inhibition at one concentration: 74.8%
Compound 4: middle estimate off by 19.8 percentage points, on the low side; the range from low to high includes it.
By their numbers in this assay, from the lowest: compound 2; then compound 3; then compounds 4 and 1 (each within the scatter of the next).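

In this assay, putting phenethyl in place of 4-methylphenyl on the sulfur gives a number 4.4 percentage points lower from compound 1 to compound 4 (within the scatter), so this position accepts a group that carries its aromatic ring on a chain, with no change beyond normal variation. The replaced group can therefore change considerably without a clear loss, so the large fall seen in a number 39 percentage points lower from compound 1 to compound 2 (beyond the scatter) does not mean that every change on this side of the molecule is costly. Nothing available explains why these two changes differ so much.

The compounds shown leave open whether the aromatic ring is needed at all, which a plain hexyl chain on the sulfur could test. They also leave open how far the chain can grow and what polar groups do here, as a 3-phenylpropyl group or a chain ending in an amine or a carboxylic acid could show.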